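The source may report more compounds than this note shows. Statements on the series, on what has been measured and on what is new or still open speak of the compounds shown alone.

Of the compounds shown here, three built on one shared core have been measured in an assay on isolated protein for binding affinity to histamine H2 receptor (Homo sapiens); a higher number here means a weaker inhibitor, a lower number a stronger inhibitor. Compound 1 `CCOC(=O)N1CCN(CCCOc2ccc(C(=O)C3CC3)cc2)CC1` gives 79400 nM in this assay. Compound 2 `CCOC(=O)N1CCN(CCCOc2ccc(C(=O)CC(C)C)cc2)CC1` gives 69200 nM. Compound 3 `C=C(C)C(=O)c1ccc(OCCCN2CCN(C(=O)OCC)CC2)cc1` gives 22400 nM, the lowest of the three numbers, so it is the strongest binder of the set. The steps leading to it were modest: a 3.5-fold lower number from compound 1 to compound 3 (0.55 log units; beyond the scatter) and a 3.1-fold lower number from compound 2 to compound 3 (0.49 log units; beyond the scatter), whereas a 1.1-fold lower number from compound 1 to compound 2 (0.06 log units; within the scatter).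

Compound 4 `CCOC(=O)N1CCN(CCCOc2ccc(C(=O)c3cccc(F)c3F)cc2)CC1` has not yet been measured. It differs from compound 3 in one place: 2,3-difluorophenyl in place of 1-methylethenyl on a carbonyl carbon. Among the measured compounds shown here, none of the measured steps puts an aromatic ring on that carbonyl carbon; all three only exchange small open or three-membered groups among themselves, and even the largest of those steps was modest. The step from compound 3 to compound 4 in this assay is thus only loosely anticipated: the expected step is a 1.3-fold higher number from compound 3 to compound 4 (0.13 log units; within the scatter), with the direction uncertain and a number not far from that of compound 3 the most likely outcome. Compound 4 is therefore estimated at 30000 nM in this assay, within a range from 8000 nM to 120000 nM.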

Compound 4, inhibition constant: 17400 nM
Compound 4: middle estimate off by 1.7-fold (0.24 log units), on the high side; the measured number falls inside the stated range.
By their numbers in this assay, from the lowest: compounds 4 and 3 (each within the scatter of the next); then compounds 2 and 1 (each within the scatter of the next).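

On the carbonyl carbon, a large aromatic group fits the trend of the small groups in this assay: 2,3-difluorophenyl, with 8 heavy atoms against the 3 of 1-methylethenyl, gives a step that cannot be told apart from no change (a 1.3-fold lower number from compound 3 to compound 4 (0.11 log units; within the scatter)). Measured against the other two groups, the aromatic ring gives modest steps of about the same size as those seen with 1-methylethenyl (a 4.0-fold lower number from compound 2 to compound 4 (0.60 log units; beyond the scatter); a 4.6-fold lower number from compound 1 to compound 4 (0.66 log units; beyond the scatter)), so compound 3 and compound 4 sit together, apart from compound 1 and compound 2, and a ring at this place costs nothing measurable in this comparison. There is no outside information on why these groups fall into two such pairs.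

Still open, from the compounds shown here alone, is whether a plain phenyl group without fluorine, or a group carrying an amine or a carboxylic acid, would give a number like these on the same carbonyl carbon. Also open, going by these compounds, is whether any group at this place can take the number far lower than that of compound 4 (17400 nM), as all the steps seen so far remain modest or smaller.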